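Ethylamino for Methylamino at a Cytotoxicity Limit

The source may hold more compounds than are shown below. What is called first, only, known or untested is meant among the compounds shown, and "the series" means these compounds.

Measured compounds:
compound 1, `CCOc1ccc(NC(=O)c2c(N)n[nH]c2NC)cc1`: > 100000 nM
compound 2, `CCOc1ccc(-n2nnc3n[nH]c(NC)c3c2=O)cc1`: > 100000 nM
compound 3, `CCOc1ccc(NC(=O)CC#N)cc1`: > 100000 nM

In an ADME assay on TERT-RPE1 cells (Homo sapiens) for cytotoxicity, read by resazurin assay, with a stated time of 48 h (on this read-out higher numbers stand for weaker inhibition and lower numbers for stronger inhibition), compound 1 gives no number, only the limit > 100000 nM. Compound 2 likewise sits at a limit, > 100000 nM. Compound 3 also sits at a limit, > 100000 nM. All three values therefore rest at the limit of > 100000 nM in this assay, at which 3 of the 3 values shown sit, so compound 1 stands level with the other two measured compounds and no order among them can be read from these numbers. Every value shown is a limit. Going by the values given here, no step between measured compounds can be sized.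

Compound 4, `CCNc1[nH]nc(N)c1C(=O)Nc1ccc(OCC)cc1`, differs from compound 1 by methyl in place of hydrogen on a saturated chain carbon bound to a nitrogen on an aromatic ring. Among the compounds with values here, with compound 1 already at the limit of this assay and no measured step to draw on, the expected step from this change is none beyond the scatter; the estimate is a step that the limit leaves unreadable from compound 1 to compound 4. Compound 4 is accordingly expected to give about 150000 nM in this assay, with a range from 60000 nM to 400000 nM, most likely reported again only as a limit.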

Compound 4, half-maximal inhibitory concentration: > 100000 nM
Compound 4: a limit, no number; the forecaster's own chance of this, stated with the estimate: 85%; the middle value lies beyond the limit too.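

In this assay compound 4 gives > 100000 nM, a limit and not a number. Going by these compounds alone, compound 1 sits at a limit as well, so no step between compound 1 and compound 4 can be read. The compounds shown leave open whether ethylamino and methylamino differ at all in this assay, and what structure would bring a measurable value.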